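Methoxy added to a compound at the assay limit

The source may report more compounds than this note shows. Statements on the series, on what has been measured and on what is new or still open speak of the compounds shown alone.

Measured so far:
compound 1 `COc1cc(-n2c(-c3ccc(O)cc3)c[nH]c2=O)cc(OC)c1OC`: > 50000 nM (a limit)
compound 2 `COc1ccc(-c2c[nH]c(=O)n2-c2cc(OC)c(OC)c(OC)c2)cc1`: > 50000 nM (a limit)

In a functional assay on K-562R cells (Homo sapiens) for cytotoxicity, read by MTT assay, with a stated time of 48 h (a lower number here means a stronger inhibitor, a higher number a weaker inhibitor), compound 2 gives > 50000 nM, which is a limit and not a number. Compound 2 thus stands, with compound 1, at the limit of > 50000 nM in this assay, at which 2 of the 2 values shown sit.

Compound 3 `COc1ccc(-c2c[nH]c(=O)n2-c2cc(OC)c(OC)c(OC)c2)cc1OC` carries one change: methoxy in place of hydrogen on an aromatic carbon. This is methoxy in place of hydrogen on an aromatic carbon.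

Among the measured compounds shown here, the one measured step that bears on it is a step that the two limits leave unreadable from compound 1 to compound 2. That change was a methyl in place of hydrogen on an oxygen on an aromatic ring, and it offers no size to carry over. For the measured compounds named here, no compound yet has a number in this assay, so no change beyond the scatter is expected. The expected step is a number no higher from compound 2 to compound 3 (the limit leaves the size open). Compound 3 is estimated at 50000 nM, within an expected range of 15000 nM to 100000 nM, and may well return only a limit.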

Compound 3, half-maximal inhibitory concentration: > 50000 nM
Compound 3: no number, only a limit (the forecaster's own chance of this, stated with the estimate: 75%); the middle value sits exactly at the limit.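

Compound 2 gives > 50000 nM, a limit and not a number. Compound 3 gives > 50000 nM, also a limit, so no step can be read between compound 2 and compound 3. The compounds shown leave open the size of any effect of these changes in this assay.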